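The source may hold more compounds than are shown below. What is called first, only, known or untested is meant among the compounds shown, and "the series" means these compounds.

Three close relatives of one scaffold have been measured for how well they dissolve. Compound 1 `CNC1CC(=O)OC1C(O)C(=O)NC(CC(C)C)C1Cc2cccc(O)c2C(=O)O1` gives 990 ug/mL in a physicochemical assay for solubility, in phosphate buffer; a lower number here means a less soluble compound, a higher number a more soluble compound. Compound 2 `CCNC1CC(=O)OC1C(O)C(=O)NC(CC(C)C)C1Cc2cccc(O)c2C(=O)O1` gives 11000 ug/mL in this assay, and compound 3 `CCCCCNC1CC(=O)OC1C(O)C(=O)NC(CC(C)C)C1Cc2cccc(O)c2C(=O)O1` gives 330 ug/mL in this assay. Between the first two, the change is methyl in place of hydrogen on a saturated chain carbon bound to an amine nitrogen, and this step was an 11-fold higher number from compound 1 to compound 2 (1.05 log units; beyond the scatter). Compound 3 differs from compound 1 by butyl in place of hydrogen on a saturated chain carbon bound to an amine nitrogen, a step of a 3.0-fold lower number from compound 1 to compound 3 (0.48 log units; beyond the scatter). Between compound 2 and compound 3 the step was a 33-fold lower number from compound 2 to compound 3 (1.52 log units; beyond the scatter). Compound 3 thus stands lowest of the three.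

Compound 4 `CCCCCCNC1CC(=O)OC1C(O)C(=O)NC(CC(C)C)C1Cc2cccc(O)c2C(=O)O1` has not yet been measured in this assay. It differs from compound 3 by methyl in place of hydrogen on a saturated chain carbon, five bonds along the chain from an amine nitrogen. For the measured compounds named here, this is the same kind of change as the one from compound 1 to compound 2, where the methyl enters on a saturated chain carbon bound to an amine nitrogen, whereas in compound 4 it enters on a saturated chain carbon five bonds along the chain from an amine nitrogen. The two changes are not the same. The expectation here rests on compound 3, whose value of 330 ug/mL lies below compound 1 and compound 2, and on the large drop seen in a 33-fold lower number from compound 2 to compound 3 (1.52 log units; beyond the scatter) as the chain grew. For compound 4 a step of a 2.5-fold lower number from compound 3 to compound 4 (0.40 log units; beyond the scatter) is expected. Compound 4 is therefore estimated at 130 ug/mL, most likely between 40 ug/mL and 400 ug/mL.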

Compound 4, solubility: 5 ug/mL
For compound 4 the middle estimate is 26-fold (1.41 log units) above the measured one; the whole stated range lies above it.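

In this assay, the methyl that extends the chain of compound 3 on a saturated chain carbon, five bonds along the chain from an amine nitrogen, gives a sharp fall (a 66-fold lower number from compound 3 to compound 4 (1.82 log units; beyond the scatter)), whereas the methyl on a saturated chain carbon bound to an amine nitrogen gives a rise (an 11-fold higher number from compound 1 to compound 2 (1.05 log units; beyond the scatter)), so even within the shared core the same kind of change does not have one fixed outcome. Compound 4 has the lowest number of the four, as the steps from the two shortest chains show (a 2200-fold lower number from compound 2 to compound 4 (3.34 log units; beyond the scatter); a 200-fold lower number from compound 1 to compound 4 (2.30 log units; beyond the scatter)), and the numbers fall as the chain grows from compound 2 through compound 3 to compound 4. Compound 1 goes against this pattern. Its chain is shorter than that of compound 2, and its number is lower. All four compounds share one core, so they show nothing about whether either step would carry over to a different core, and no measurement is available that explains the size or direction of these steps.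

From the compounds shown here alone, how a propyl or butyl chain on the amine nitrogen would read remains open, so the point at which the numbers begin to fall is not fixed. Also open, going by these compounds, is how a chain longer than that of compound 4, or a chain ending in a carboxylic acid, would behave in this assay.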